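Swapping methyl for trifluoromethyl on a bicyclic core

The source may report more compounds than this note shows. Statements on the series, on what has been measured and on what is new or still open speak of the compounds shown alone.

Measured so far:
compound 1, `CC(C)n1c(=O)[nH]c2ncc(Br)nc21`: "not determined" (no result reported)
compound 2, `CCC(CC)n1c(=O)[nH]c2nccnc21`: "not determined" (no result reported)
compound 3, `CCC(CC)n1c(=O)[nH]c2ncc(C)nc21`: 0.7

All three compounds share a fused two-ring core; in an ADME assay on microsomes from liver (Rattus norvegicus), read by LC-MS, with a stated time of 90 min (a lower number here means that the liver removes a smaller share, a higher number that the liver removes a larger share of the compound in one pass), only compound 3 has a number, 0.7, which places it well toward the upper end of what this assay can report. Within the data shown here, compound 1 and compound 2 carry no result, so there is no measured step between any two compounds here, and nothing to show how a change on the ring shifts the read-out.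

The unmeasured compound 4, `CCC(CC)n1c(=O)[nH]c2ncc(C(F)(F)F)nc21`, differs from compound 3 in one place: trifluoromethyl in place of methyl on an aromatic carbon. Without any measured step to lean on, the expectation rests on compound 3 alone, and the step is expected to be small, no larger than the usual scatter, with if anything a slight drift downward a number 0.10 lower from compound 3 to compound 4 (within the scatter). Compound 4 is therefore estimated at 0.6, within a range of 0.35 to 0.85.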

Compound 4, hepatic extraction ratio: 0.2
For compound 4 the middle estimate is 0.40 above the measured one; measured number below the stated range.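

In this assay, this place on the shared core, an aromatic carbon next to the ring nitrogen, proves sensitive to what sits on it: trifluoromethyl in place of methyl gives a number 0.50 lower from compound 3 to compound 4 (beyond the scatter). Among these compounds, the earlier compounds offered no measured step, so this is the first sign that one change here, with the 1-ethylpropyl-type side chain and the rest of the molecule kept the same, can move the liver's one-pass removal well beyond ordinary variation. Nothing shown here gives a reason for a step of this size.

Still open, going by these compounds, is whether this step belongs to trifluoromethyl alone or would also appear with another group at this place, such as a nitrile, a methoxy group or an amine. One step also cannot show whether the same swap would act alike with a different chain on the ring nitrogen, such as a longer alkyl chain.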